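Exchanging 3-methoxybenzyl for 2-(diethylamino)ethyl on a shared core

This account rests on a few compounds, and the source may have more. Where it says the series, first, only, none or still open, it means among the compounds named here.

Three compounds with a shared core have entries in an ADME assay on J774.A1 cells (Mus musculus) for cytotoxicity, read by MTT assay, with a stated time of 48 h; a lower number here means that less compound is tolerated, a higher number that more compound is tolerated: compound 1 `COC(=O)c1c(NCc2ccc(F)cc2)noc1-c1ccc([N+](=O)[O-])cc1`, compound 2 `COC(=O)c1c(NCc2ccc(Cl)cc2)noc1-c1ccc([N+](=O)[O-])cc1` and compound 3 `COC(=O)c1c(NCc2cccc(OC)c2)noc1-c1ccc([N+](=O)[O-])cc1`. Only one of them has a number, as compound 2 gives 78300 nM. The entry for compound 1 reads "not determined" (no result reported). For the measured compounds named here, the entry for compound 3 reads "not determined" (no result reported), so compound 3 has no position on the scale, and no step between measured compounds is available.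

Compound 4 `CCN(CC)CCNc1noc(-c2ccc([N+](=O)[O-])cc2)c1C(=O)OC` is still to be measured. Its structural change is (diethylamino)methyl in place of 3-methoxyphenyl on a saturated chain carbon bound to a nitrogen on an aromatic ring, with (diethylamino)methyl in place of 3-methoxyphenyl on a saturated chain carbon bound to a nitrogen on an aromatic ring. Cut one bond further out, this reads 3-methoxybenzyl to 2-(diethylamino)ethyl.

Going by the values given here, the only available anchor is compound 2 at 78300 nM. Against that number, a modest step towards a lower value is expected in this assay, although the direction remains uncertain. For compound 4, the estimated value is 45000 nM, with an expected range from 12000 nM to 150000 nM.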

Compound 4, half-maximal cytotoxic concentration: 69300 nM
Estimate against measurement, compound 4: 1.5-fold (0.19 log units) below; measured number inside the range.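

In this assay, the exchange of 4-chlorophenyl for (diethylamino)methyl on a saturated chain carbon bound to a nitrogen on an aromatic ring gives a 1.1-fold lower number from compound 2 to compound 4 (0.05 log units; within the scatter), so for this pair a group with an aromatic ring of carbon only and a group with no ring cannot be told apart. The exchange of 3-methoxybenzyl for 2-(diethylamino)ethyl itself cannot be read, as compound 3 has no number, and neither can any step from compound 1. Nothing given here accounts for this result.

On these data alone, whether this single comparison extends to other groups at this position remains open, for example a 3-(diethylamino)propyl chain, a morpholine ring or a carboxylic acid. As far as these compounds go, it is also open whether the same exchange would give a similar result on a core carrying something other than the methyl ester.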